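Adding a (dimethylamino)methyl group to compound 3

The compounds below may be only part of what the source reports. "The series", "measured", "known", "first", "only" and "open" are said of these compounds alone.

Measured in a functional assay on CCRF-CEM cells (Homo sapiens); on this read-out higher numbers stand for weaker inhibition and lower numbers for stronger inhibition:
- compound 1 `Cc1ccc(/C=C/C(=O)Oc2ccc(/C=C3\CCCC(CN(C)C)C3=O)cc2)cc1`: 7020 nM
- compound 2 `CN(C)CC1CCC/C(=C\c2ccc(OC(=O)/C=C/c3ccc(F)cc3)cc2)C1=O`: 6000 nM
- compound 3 `COc1ccc(C(=O)Oc2ccc(/C=C3\CCCCC3=O)cc2)cc1`: 36100 nM

At 36100 nM, compound 3 has the highest number of the three, and its gaps to compound 1 and compound 2 both lie beyond the scatter. The next analogue, compound 4 `COc1ccc(C(=O)Oc2ccc(/C=C3\CCCC(CN(C)C)C3=O)cc2)cc1`, differs from it by one change: (dimethylamino)methyl in place of hydrogen on a saturated ring carbon.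

Among the compounds with values here, no measured step isolates this change. Within the data shown here, the only step available, a 1.2-fold lower number from compound 1 to compound 2 (0.07 log units; within the scatter), swaps fluoro for methyl on an aromatic carbon, so it says little here beyond showing that this one swap left the number within the scatter. The indirect evidence is that compound 1 at 7020 nM and compound 2 at 6000 nM both carry the (dimethylamino)methyl group, though they also differ from compound 3 elsewhere. A move towards a lower number is therefore expected, with wide uncertainty.

The expected change is a 4.5-fold lower number from compound 3 to compound 4 (0.65 log units; beyond the scatter).

For compound 4 the estimated value is 8000 nM, with an expected range of 2500 nM to 25000 nM.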

Compound 4, half-maximal inhibitory concentration: 5070 nM
Estimate against measurement, compound 4: 1.6-fold (0.20 log units) above; the range from low to high includes it.
By their numbers in this assay, from the lowest: compounds 4, 2 and 1 (each within the scatter of the next); then compound 3.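

In this assay there is now a direct reading of this position: (dimethylamino)methyl in place of hydrogen on the saturated ring carbon gives a 7.1-fold lower number from compound 3 to compound 4 (0.85 log units; beyond the scatter) with the rest of the molecule held constant. Among the compounds carrying this group, the group on the carbonyl carbon does not separate the numbers: 4-methoxyphenyl in place of 2-(4-fluorophenyl)ethenyl gives a 1.2-fold lower number from compound 2 to compound 4 (0.07 log units; within the scatter) and 4-methoxyphenyl in place of 2-(4-methylphenyl)ethenyl gives a 1.4-fold lower number from compound 1 to compound 4 (0.14 log units; within the scatter) on the same read-out. No measurement shown accounts for the size of the step from hydrogen.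

Within the data shown here, compound 3 is the only compound without the group, so the step is known with 4-methoxyphenyl on the carbonyl carbon alone. Also open, as far as these compounds go, is how a longer chain such as (dimethylamino)ethyl, or a morpholinylmethyl group, would read on the same ring carbon.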